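A few compounds are considered here, and "the series" means these few. Any claim that something is new, unique, unknown or untested is made for them only; others in the source may bear on it.

Measured so far:
compound 1 `COc1ccc2cc(CCCO)oc(=O)c2c1` — 25.9 ug/mL
compound 2 `CCCCCOCCCc1cc2ccc(OC)cc2c(=O)o1` — 8 ug/mL

In a functional assay on PC-3 cells (Homo sapiens) for antiproliferative activity, read by sulforhodamine B assay, with a stated time of 48 h (a higher number here means a weaker inhibitor of growth, a lower number a stronger inhibitor of growth), compound 2 gives the lowest of the two numbers; its nearest neighbour is compound 1, separated by a 3.2-fold lower number from compound 1 to compound 2 (0.51 log units; beyond the scatter), a modest step beyond the scatter. Compound 3 `COc1ccc2cc(CCCOCCCc3cccnc3)oc(=O)c2c1` carries pyridin-3-yl in place of ethyl on a saturated chain carbon, three bonds along the chain from an oxygen on a saturated carbon. For the measured compounds named here, no measured step alters that end of the chain; the single step, a 3.2-fold lower number from compound 1 to compound 2 (0.51 log units; beyond the scatter), lies on the same chain but concerns a different position, so it bears only loosely here. The expectation is a step no larger than that one, a 1.1-fold lower number from compound 2 to compound 3 (0.06 log units; within the scatter), in either direction. Compound 3 is estimated at 7 ug/mL, with a range of 3 ug/mL to 18 ug/mL.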

Compound 3, concentration for 50% growth inhibition: 26.3 ug/mL
Beside the measured number, compound 3's estimate is 3.8-fold (0.57 log units) below it, outside the stated range (above it).
By their numbers in this assay, from the lowest: compound 2; then compounds 1 and 3 (each within the scatter of the next).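

In this assay, the far end of the chain responds to change: pyridin-3-yl in place of ethyl gives a 3.3-fold higher number from compound 2 to compound 3 (0.52 log units; beyond the scatter), a modest step. The improvement seen with the pentyl ether of compound 2 is therefore not shared by every ether on this chain, since compound 3 lies within the scatter of compound 1. No evidence on hand accounts for this step.

Still open, from the compounds shown here alone, is whether phenyl at the same place behaves like ethyl or like pyridin-3-yl. A longer alkyl chain or a terminal amine is equally unresolved.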